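A few compounds are considered here, and "the series" means these few. Any claim that something is new, unique, unknown or untested is made for them only; others in the source may bear on it.

Compound 1 `COC(=O)CCCCCOc1cc(-c2ccccc2)cc(-c2ccccc2)n1`: in an assay on cell membranes from spleen (Cavia porcellus) for binding affinity to leukotriene B4 receptor 1 (Homo sapiens) (on this read-out higher numbers stand for weaker inhibition and lower numbers for stronger inhibition), compound 1 gives 40 nM.
Compound 2 `COc1ccc(-c2cc(-c3ccccc3)cc(OCCCCCC(=O)O)n2)cc1`: in this assay compound 2 gives 1000 nM.
Compound 3 `O=C(O)CCCCCOc1cc(-c2ccccc2)cc(-c2ccccc2)n1`: in this assay compound 3 gives 3 nM.

Compound 3 stands lowest of the three numbers. Its nearest neighbour is compound 1, separated by a 13-fold lower number from compound 1 to compound 3 (1.12 log units; beyond the scatter), and its furthest is compound 2, separated by a 330-fold lower number from compound 2 to compound 3 (2.52 log units; beyond the scatter). Compound 4 `O=C(O)CCCCCCOc1cc(-c2ccccc2)cc(-c2ccccc2)n1` has not yet been measured in this assay. It differs from compound 3 in one place: carboxymethyl in place of carboxy on a saturated chain carbon, five bonds along the chain from an oxygen on an aromatic ring. Neither measured step bears directly on this change. The step from the methyl ester to the free acid, a 13-fold lower number from compound 1 to compound 3 (1.12 log units; beyond the scatter), and the step from the methoxy-bearing ring to the bare ring, a 330-fold lower number from compound 2 to compound 3 (2.52 log units; beyond the scatter), were both large, but both left the chain as it stands in compound 3, so they give no guide to carboxymethyl in place of carboxy on a saturated chain carbon. Among the compounds with values here, with no guiding step, compound 4 is expected to differ from compound 3 by a 1.3-fold higher number from compound 3 to compound 4 (0.12 log units; within the scatter), a step within the scatter. Compound 4 is therefore estimated at 4 nM, with a range from 1.5 nM to 12 nM.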

Compound 4, half-maximal inhibitory concentration: 25 nM
Compound 4: middle estimate off by 6.3-fold (0.80 log units), on the low side; measured number above the stated range.
By their numbers in this assay, from the lowest: compound 3; then compounds 4 and 1 (each within the scatter of the next); then compound 2.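

In this assay this place on the chain proves sensitive: carboxymethyl in place of carboxy, five bonds along the chain from an oxygen on an aromatic ring, gives an 8.3-fold higher number from compound 3 to compound 4 (0.92 log units; beyond the scatter) and so a small extension of the chain is enough to move the number beyond the scatter. The free acid alone therefore does not secure the low number of compound 3, since the comparison with the methyl ester gives a 1.6-fold lower number from compound 1 to compound 4 (0.20 log units; within the scatter) and places the two within the scatter of each other. Nothing available here accounts for this sensitivity.

The compounds shown leave open whether the trend continues with 2-carboxyethyl or 3-carboxypropyl at this place, or whether the number recovers at some chain length. They also leave open how a shorter chain ending in a carboxylic acid would read on the same core.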